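A chloro for methoxy swap on compound 1

The source may hold more compounds than are shown below. What is called first, only, known or untested is meant among the compounds shown, and "the series" means these compounds.

Measured in a functional assay on MCF7 cells (Homo sapiens) for inhibition, read by MTT assay, with a stated time of 48 h; on this read-out lower numbers stand for stronger inhibition and higher numbers for weaker inhibition:
- compound 1 `COc1ccc(C(=O)C=CNc2cc(-c3ccccc3)nn2-c2ccccc2)cc1` gives 1290 nM
- compound 2 `Cc1ccc(-c2ccnc3c2c(-c2ccccc2)nn3-c2ccccc2)cc1` gives 5590 nM
- compound 3 `Fc1ccc(-c2ccnc3c2c(-c2ccccc2)nn3-c2ccccc2)cc1` gives 1570 nM

Compound 1 and compound 3 lie within the scatter of each other, while compound 2 has a higher number than compound 1, beyond the scatter. Compound 4 `O=C(C=CNc1cc(-c2ccccc2)nn1-c1ccccc1)c1ccc(Cl)cc1` has not yet been measured. It differs from compound 1 at one place: chloro in place of methoxy on an aromatic carbon, with 4-methoxyphenyl becoming 4-chlorophenyl. Among the measured compounds shown here, only one measured step bears on this, and only loosely. The modest step of a 3.6-fold lower number from compound 2 to compound 3 (0.55 log units; beyond the scatter) puts fluoro in place of methyl on a core other than that of compound 1, and neither group is involved in the new change. A small drop, possibly within the scatter, is therefore expected in this assay. The expected step is a 1.3-fold lower number from compound 1 to compound 4 (0.11 log units; within the scatter). For compound 4 the estimated value is 1000 nM, with an expected range of 350 nM to 2900 nM.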

Compound 4, half-maximal inhibitory concentration: 8070 nM
Compound 4: the middle estimate sits 8.1-fold (0.91 log units) below what was measured, outside the stated range (above it).
By their numbers in this assay, from the lowest: compounds 1 and 3 (each within the scatter of the next); then compounds 2 and 4 (each within the scatter of the next).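

In this assay, chloro in place of methoxy on this aromatic carbon, para to a large group, gives a 6.3-fold higher number from compound 1 to compound 4 (0.80 log units; beyond the scatter). This shows that the place is sensitive to the change on the core of compound 1, and that the step measured on the other core does not predict its direction here. No measured evidence accounts for the difference. On these data alone, it remains open whether an amine or a hydroxyl group at this place would track with 4-methoxyphenyl or 4-chlorophenyl. As far as these compounds go, whether the same swap behaves alike on the core of compound 2 also remains open.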